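Working notes on an antiproliferative series

This account rests on a few compounds, and the source may have more. Where it says the series, first, only, none or still open, it means among the compounds named here.

Measured compounds:
compound 1 `CCN1C(=O)C(=O)c2cc(-c3ccc(OC)cc3)ccc21` 4470 nM
compound 2 `CCOC(=O)/C=C1\C(=O)N(Cc2ccc(OC)cc2)c2ccc(-c3ccc(OC)cc3)cc21` 3390 nM
compound 3 `COC(=O)/C=C1\C(=O)N(Cc2ccc(OC)cc2)c2ccc(-c3ccc(OC)cc3)cc21` 4730 nM

All three were read in a functional assay on HepG2 cells (Homo sapiens) for antiproliferative activity, read by MTT assay, with a stated time of 48 h; on this read-out lower numbers stand for stronger inhibition and higher numbers for weaker inhibition. Among the measured compounds shown here, compound 3 sits with the other two: the gap to compound 1 is within the scatter, and the one measured step, a 1.4-fold higher number from compound 2 to compound 3 (0.14 log units; within the scatter), is also within the scatter, so on these numbers compound 3 is not separable from compound 1 or compound 2.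

Compound 4 `COc1ccc(CN2C(=O)/C(=C\c3ccccc3)c3cc(-c4ccc(OC)cc4)ccc32)cc1` has not been measured. Relative to compound 3 it carries phenyl in place of methoxycarbonyl on a double-bonded chain carbon bound to a double-bonded ring carbon. For the measured compounds named here, the only single-point step available, from compound 2 to compound 3, touches the alkyl on the ester oxygen and left the number essentially unchanged; no measured pair swaps the ester for an aromatic ring, so there is no direct precedent for the present change.

With nothing bearing on the ester-to-phenyl swap, the working expectation for compound 4 in this assay is a step of about a 1.2-fold lower number from compound 3 to compound 4 (0.07 log units; within the scatter), that is, no movement beyond the scatter. Going by the values given here, the estimated value for compound 4 is 4000 nM, with a range from 1300 nM to 12000 nM, kept wide because the change has no measured analogue in the set.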

Compound 4, half-maximal inhibitory concentration: > 10000 nM
Compound 4: only a limit was reported (the forecaster's own chance of this, stated with the estimate: 5%); at least 2.5-fold (0.39 log units) between middle value and limit.
By their numbers in this assay, from the lowest: compounds 2, 1 and 3 (each within the scatter of the next). At a limit, above all of these: compound 4.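

In this assay compound 4 gives only a limit, not a number, > 10000 nM, and it is the one compound in the series to do so: the limit of > 10000 nM in this assay, at which 1 of the 4 values shown sits.

The phenyl swap gives an at least 2.1-fold higher number from compound 3 to compound 4 (0.32 log units; beyond the scatter) and, against the ethyl ester, an at least 2.9-fold higher number from compound 2 to compound 4 (0.46 log units; beyond the scatter). Among the compounds shown here, these are the first steps beyond the scatter, so the position on a double-bonded chain carbon bound to a double-bonded ring carbon does respond to a change of group, whereas changing the ester's alkyl part gave only a 1.4-fold higher number from compound 2 to compound 3 (0.14 log units; within the scatter). On these data alone, since compound 4 sits at a limit, the full size of the loss stays unknown.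

The compounds shown do not tell whether losing the ester or bringing in the phenyl ring drives the step. A carboxylic acid, a primary amide or a longer ester chain at this position would help separate the two.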